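Extending a Short Chain on Compound 3

The compounds below may be only part of what the source reports. "The series", "measured", "known", "first", "only" and "open" are said of these compounds alone.

In a functional assay on MCF7 cells (Homo sapiens) for antiproliferative activity, read by MTT assay, with a stated time of 72 h (a higher number here means a weaker inhibitor, a lower number a stronger inhibitor), compound 3 `CC(=O)NNC(=O)c1csc2ncc(-c3ccc(C)cc3)n12` gives 57300 nM. That is level with compound 2 `O=C(NCc1ccccc1)c1csc(NC(=S)Nc2ccc(Cl)cc2)n1` at 56500 nM, while compound 1 `COc1ccc(NC(=S)Nc2nc(C(=O)NCc3ccccc3)cs2)cc1` gives 24600 nM, a lower number and so a stronger result. Compound 4 `CCCC(=O)NNC(=O)c1csc2ncc(-c3ccc(C)cc3)n12` carries ethyl in place of hydrogen on a saturated chain carbon bound to a carbonyl carbon, which turns methyl to propyl: ethyl in place of hydrogen on a saturated chain carbon bound to a carbonyl carbon. Going by the values given here, no measured step touches this chain. The only one, a 2.3-fold higher number from compound 1 to compound 2 (0.36 log units; beyond the scatter), swaps chloro in place of methoxy on an aromatic carbon on a different core, so it offers only a rough sense of size. The expected change is small, with no firm direction: a 1.1-fold lower number from compound 3 to compound 4 (0.06 log units; within the scatter). For compound 4 the estimate is 50000 nM, with an expected range of 20000 nM to 120000 nM.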

Compound 4, half-maximal inhibitory concentration: 41700 nM
For compound 4 the middle estimate is 1.2-fold (0.08 log units) above the measured one; the measured number falls inside the stated range.
By their numbers in this assay, from the lowest: compounds 1, 4, 2 and 3 (each within the scatter of the next, the first and the last beyond it).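

Going by these compounds alone, this is the only measured step at this saturated chain carbon bound to a carbonyl carbon: this assay shows a 1.4-fold lower number from compound 3 to compound 4 (0.14 log units; within the scatter) and so the two compounds cannot be told apart. Going from methyl to propyl therefore adds ethyl here with no effect that stands clear of the scatter. Nothing measured on these compounds offers an explanation for this result. Still open, from the compounds shown here alone, is whether a longer chain, a phenyl ring or an amine at this same carbon would move the number beyond the scatter.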